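The source may hold more compounds than are shown below. What is called first, only, known or untested is meant among the compounds shown, and "the series" means these compounds.

In a functional assay on HaCaT cells (Homo sapiens) for antiproliferative activity, read by sulforhodamine B assay, with a stated time of 3 days (a lower number here means a stronger inhibitor, a higher number a weaker inhibitor), compound 1 `COC(=O)c1cc(CCc2cccc(OC)c2)ccc1O` gives 37000 nM and sits at the top of the range so far, level with compound 2 `COC(=O)c1cc(CCc2cccc(OC)c2OC)ccc1O` at 33000 nM. Compound 3 `COC(=O)c1cc(CCc2cc(Cl)ccc2OC)ccc1O` lies clearly lower at 6900 nM. Compound 4 `COC(=O)c1cc(CCc2cc(OC)ccc2Br)ccc1O` differs from compound 1 by bromo in place of hydrogen on an aromatic carbon, ortho to a large group and para to a methoxy group. Within the data shown here, the only measured single change, a 1.1-fold lower number from compound 1 to compound 2 (0.05 log units; within the scatter), adds a methoxy and says little about a bromo. The closest guide is chloro-bearing compound 3 at 6900 nM, which points towards a lower number. The expected change is a 3.1-fold lower number from compound 1 to compound 4 (0.49 log units; beyond the scatter), a moderate gain in this assay. The estimate for compound 4 is 12000 nM, with an expected range from 4000 nM to 33000 nM.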

Compound 4, half-maximal inhibitory concentration: 210 nM
The estimate for compound 4 lay 57-fold (1.76 log units) above the measured number; measured number outside the range, below it.
By their numbers in this assay, from the lowest: compound 4; then compound 3; then compounds 2 and 1 (each within the scatter of the next).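

In this assay the step is a 180-fold lower number from compound 1 to compound 4 (2.25 log units; beyond the scatter) for bromo in place of hydrogen on an aromatic carbon, ortho to a large group and para to a methoxy group, so the number is highly sensitive to substitution at this carbon. Among these compounds, the only earlier single change gave a 1.1-fold lower number from compound 1 to compound 2 (0.05 log units; within the scatter) with a methoxy in place of hydrogen, so a large step on this ring was not yet on record. Nothing on hand explains the size of the bromo step.

Going by these compounds, whether the step is specific to bromo stays open, and iodo, methyl or trifluoromethyl at this carbon would test it. Also open, on these data alone, is whether it holds when the methyl ester gives way to a carboxylic acid or an amide.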